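Removing an Aromatic Trifluoromethyl Group: Two Cores Compared

This account rests on a few compounds, and the source may have more. Where it says the series, first, only, none or still open, it means among the compounds named here.

Measured compounds in an ADME assay on MT4 cells (Homo sapiens) for cytotoxicity, read by MTT assay, with a stated time of 96 h; a higher number here means that more compound is tolerated, a lower number that less compound is tolerated:
compound 1, `CN(C)CCCN(/N=N/c1cc(F)ccc1F)c1ccccc1`, 13000 nM
compound 2, `Cc1c(/N=N/c2cccc(C(F)(F)F)c2)ccc(NC[C@@H]2CCCN3CCCC[C@H]23)c1C`, 77000 nM
compound 3, `CN(C)CCCN(/N=N/c1cc(F)ccc1F)c1cccc(C(F)(F)F)c1`, 16000 nM

Compound 3 and compound 1 share one core and differ by a single change, (hydrogen in place of trifluoromethyl on an aromatic carbon). The step in this assay is a 1.2-fold lower number from compound 3 to compound 1 (0.09 log units; within the scatter). Compound 2 has a different core; how it differs from compound 3 is not broken down here. In this assay compound 2 gives the highest number of the three, a gap to compound 3 and to compound 1 that lies beyond the scatter.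

Compound 4, `Cc1c(/N=N/c2ccccc2)ccc(NC[C@@H]2CCCN3CCCC[C@H]23)c1C`, has not yet been measured. It stands to compound 2 as compound 1 stands to compound 3: hydrogen in place of trifluoromethyl on an aromatic carbon. The place of the change is the same on both cores, so the same change is made here. Because a 1.2-fold lower number from compound 3 to compound 1 (0.09 log units; within the scatter), the author expects a similarly small step, a 1.2-fold lower number from compound 2 to compound 4 (0.07 log units; within the scatter), from compound 2 to compound 4. The estimate for compound 4 in this assay is therefore 65000 nM, expected to fall between 30000 nM and 140000 nM.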

Compound 4, half-maximal cytotoxic concentration: 31000 nM
Compound 4: the middle estimate sits 2.1-fold (0.32 log units) above what was measured; measured number inside the range.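

On the core of compound 2, putting hydrogen in place of trifluoromethyl gives, in this assay, a 2.5-fold lower number from compound 2 to compound 4 (0.40 log units; beyond the scatter), a modest step. Set beside the same change on the core of compound 3, this step cannot be told apart from the earlier one: the same change on two cores in this assay, a 1.2-fold lower number (0.09 log units; within the scatter) from compound 3 to compound 1 and a 2.5-fold lower number (0.40 log units; beyond the scatter) from compound 2 to compound 4, 2.0-fold (0.30 log units) apart, within the scatter of two such steps. Among the compounds shown here, the change therefore carries from one core to the other without a difference that can be resolved, even though only the step on the core of compound 2 lies beyond the scatter by itself; with a single pair on each core, this does not show that the two steps are equal, that the result extends to a third core, or why either step has its size.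

The compounds shown leave open how a nitrile, a methoxy group or a chlorine atom on that aromatic carbon would compare with hydrogen and trifluoromethyl on these two cores in this assay. They also leave open whether the step would stay as small on a core carrying a carboxylic acid or a longer chain.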